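The source may report more compounds than this note shows. Statements on the series, on what has been measured and on what is new or still open speak of the compounds shown alone.

Working notes on the series. Two compounds carry numbers in an ADME assay on HEp-2 cells (Homo sapiens) for cytotoxicity; a lower number here means that less compound is tolerated, a higher number that more compound is tolerated. Compound 1 `CC(C)CCn1c(Cn2c(=O)n(C(C)C)c3ccccc32)nc2cc(C(C)(C)N)ccc21` gives 3270 nM in this assay. Compound 2 `CC(C)CCn1c(Cn2c(=O)n(C(C)C)c3ccccc32)nc2ccc(CN(C)C)cc21` gives 26700 nM in this assay. Of the two numbers, compound 1 holds the lower, and the gap up to compound 2 lies beyond the scatter of repeated measurements. Within the data shown here, the two compounds differ in more than one place, so no single-change step is available between them, and the two values are noted side by side without further reading.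

Compound 3 `CC(C)CCn1c(Cn2c(=O)n(C(C)C)c3ccccc32)nc2cc(C(=O)N(C)C)ccc21` has not yet been measured in this assay. Relative to compound 1 the change is dimethylcarbamoyl in place of 1-amino-1-methylethyl on an aromatic carbon. Among the measured compounds shown here, with no measured single-change step in the set, the expectation for compound 3 rests only on the spread of the two known values. The step from compound 1 to compound 3 is estimated at a 2.4-fold higher number from compound 1 to compound 3 (0.39 log units; beyond the scatter), an expected move upward of modest size that may or may not clear the scatter. For compound 3 in this assay the estimate is 8000 nM, with a range from 2500 nM to 30000 nM.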

Compound 3, half-maximal cytotoxic concentration: 25600 nM
Compound 3: middle estimate off by 3.2-fold (0.51 log units), on the low side; the range from low to high includes it.
By their numbers in this assay, from the lowest: compound 1; then compounds 3 and 2 (each within the scatter of the next).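

Among these compounds, on the aromatic carbon meta to a fused ring and para to a fused ring, dimethylcarbamoyl in place of 1-amino-1-methylethyl gives in this assay a 7.8-fold higher number from compound 1 to compound 3 (0.89 log units; beyond the scatter) and so provides the first single-change reading, showing that the number responds to what this carbon carries. The change swaps a group with a hydrogen-bond donor for one with none and adds a double bond outside aromatic rings, while neither group has a net charge, and this one step cannot separate these differences from one another. No supporting measurement in the available data accounts for the shift.

Going by these compounds, it remains open whether a carboxylic acid, a primary amide or an aminomethyl group on the same aromatic carbon would give a number close to that of compound 1 or that of compound 3. On these data alone, it also remains open whether the same step would hold on a core with a shorter alkyl chain in place of the chain shared by these compounds.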